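A few compounds are considered here, and "the series" means these few. Any claim that something is new, unique, unknown or untested is made for them only; others in the source may bear on it.

In a functional assay on SH-SY5Y cells (Homo sapiens) for antiproliferative activity, read by MTT assay, with a stated time of 48 h (a higher number here means a weaker inhibitor of growth, a lower number a stronger inhibitor of growth), compound 1 (`COc1ccccc1OCCNc1cnn(Cc2ccc(OC)c(OCC3CC3)c2)c(=O)c1Cl`) gives 37900 nM. Compound 2 (`COc1ccc(Cn2nc(NCCOc3ccccc3OC)ccc2=O)cc1Br`) gives > 100000 nM, which is a limit of the assay. Compound 3 (`COc1ccccc1OCCNc1cnn(Cc2ccc(OC)c(-c3cccc(Cl)c3)c2)c(=O)c1Cl`) gives > 100000 nM, which is also a limit and not a number. Compound 3 therefore stands at the limit of > 100000 nM in this assay, at which 2 of the 3 values shown sit, alongside compound 2.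

Compound 4 (`COc1ccccc1OCCNc1cnn(Cc2ccc(OC)c(OC3CCCC3)c2)c(=O)c1Cl`) carries cyclopentyloxy in place of 3-chlorophenyl on an aromatic carbon, ortho to a methoxy group: cyclopentyloxy in place of 3-chlorophenyl on an aromatic carbon.

For the measured compounds named here, one measured step bears on this change: an at least 2.6-fold higher number from compound 1 to compound 3 (0.42 log units; beyond the scatter). There, 3-chlorophenyl replaced cyclopropylmethoxy at the same place, so the change to compound 4 runs the opposite way, with a different ring-bearing ether group entering. A lower number is therefore expected in this assay, of a size at least comparable to the measured step, and the expectation rests on compound 1 at 37900 nM. The expected step is an at least 2.2-fold lower number from compound 3 to compound 4 (0.34 log units; beyond the scatter). For compound 4 the estimated value is 45000 nM, with an expected range from 15000 nM to 100000 nM.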

Compound 4, concentration for 50% growth inhibition: 23300 nM
For compound 4 the middle estimate is 1.9-fold (0.29 log units) above the measured one, within the range that was stated.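

With cyclopentyloxy at this place, ortho to a methoxy group, this assay shows an at least 4.2-fold lower number from compound 3 to compound 4 (0.63 log units; beyond the scatter), so a second ring-bearing ether, and not cyclopropylmethoxy alone, gives a measurable number where 3-chlorophenyl does not. The two ethers themselves cannot be told apart, as the step between them is a 1.6-fold lower number from compound 1 to compound 4 (0.21 log units; within the scatter), and swapping cyclopropylmethyl for cyclopentyl on this oxygen therefore shows no change in this assay. The size of the step from 3-chlorophenyl stays open-ended, as the value of compound 3 is a limit and not a number: the limit of > 100000 nM in this assay, at which 2 of the 4 values shown sit.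

The compounds shown leave open how a longer open chain on this oxygen, or a plain ethoxy group, would read in this assay, as both ethers here carry a ring. They also leave open what an amine or a carboxylic acid at this place would do.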